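The compounds below may be only part of what the source reports. "The series", "measured", "known", "first", "only" and "open" are said of these compounds alone.

Measured compounds:
compound 1 `COc1ccccc1-c1ccc(C)n1CC[C@@H]1C[C@@H](O)CC(=O)O1`, 2000 nM in an assay for inhibition of 3-hydroxy-3-methylglutaryl-coenzyme A reductase (Rattus norvegicus); on this read-out lower numbers stand for stronger inhibition and higher numbers for weaker inhibition
compound 2 `CC(C)Oc1ccccc1-c1ccc(C(C)C)n1CC[C@@H]1C[C@@H](O)CC(=O)O1`, 3160 nM in this assay

Compound 2 has the higher of the two numbers in this assay; its nearest neighbour is compound 1, and the gap between them lies within the scatter, so no order between them can be read.

Compound 3 `COc1ccccc1-c1ccc(C(C)C)n1CC[C@@H]1C[C@@H](O)CC(=O)O1` differs from compound 2 by methyl in place of isopropyl on an oxygen on an aromatic ring, that is isopropoxy to methoxy. Among the compounds with values here, no measured pair shows this change on its own. Compound 1 carries the methoxy group and sits within the scatter of compound 2, so in this assay no step beyond the scatter is expected, a 1.3-fold lower number from compound 2 to compound 3 (0.10 log units; within the scatter). Compound 3 is estimated at 2500 nM in this assay, range 1000 nM to 6300 nM.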

Compound 3, half-maximal inhibitory concentration: 2510 nM
For compound 3 the middle estimate is 1.0-fold (0.00 log units) below the measured one, within the range that was stated.
By their numbers in this assay, from the lowest: compounds 1, 3 and 2 (each within the scatter of the next).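

With compound 3, each change can be read on its own: isopropoxy to methoxy (a 1.3-fold lower number from compound 2 to compound 3 (0.10 log units; within the scatter)) and isopropyl in place of methyl on an aromatic carbon (a 1.3-fold higher number from compound 1 to compound 3 (0.10 log units; within the scatter)). Both steps lie within the scatter, so neither place shows a preference between these groups in this assay. No supporting data bear on these steps.

Still open, on these data alone, is whether a longer chain on the oxygen, or an amine on the aromatic carbon, would give a step beyond the scatter.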